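The source may report more compounds than this note shows. Statements on the series, on what has been measured and on what is new or still open speak of the compounds shown alone.

Measured in a functional assay on A549 cells (Homo sapiens) for inhibition, read by MTT assay; a higher number here means a weaker inhibitor, a lower number a stronger inhibitor:
- Compound 1 `CC[C@@H](C)C[C@@H](C)/C=C(C)/C=C/C=C/C(=O)c1c(O)c(C2=CC[C@@H](O)CC2)cn(O)c1=O`: 1590 nM
- Compound 2 `CC[C@@H](C)C[C@@H](C)/C=C(C)/C=C/C=C/C(=O)c1c(O)c([C@]23CC[C@H](CC2)O3)cn(O)c1=O`: > 150000 nM; > 120000 nM (2 entries) (limits of the assay, not numbers)

Among the measured compounds shown here, compound 1, at 1590 nM, is the only compound with an actual number in this assay. Compound 3 `CC[C@@H](C)C[C@@H](C)/C=C(C)/C=C/C=C/C(=O)c1c(O)c([C@]2(O)CC[C@@H](O)CC2)cn(O)c1=O` has not yet been measured. It has 1,4-dihydroxycyclohexyl in place of 4-hydroxycyclohex-1-en-1-yl on an aromatic carbon. For the measured compounds named here, a weakening beyond the usual scatter is expected, and its only support is compound 2, whose > 150000 nM; > 120000 nM (2 entries) is a limit. The estimated change is a 7.5-fold higher number from compound 1 to compound 3 (0.88 log units; beyond the scatter). For compound 3 the estimate is 12000 nM, with an expected range from 2500 nM to 70000 nM.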

Compound 3, half-maximal inhibitory concentration: 1750 nM
Compound 3: the middle estimate sits 6.9-fold (0.84 log units) above what was measured, and the stated range ends above it.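

In this assay, 1,4-dihydroxycyclohexyl in place of 4-hydroxycyclohex-1-en-1-yl gives a 1.1-fold higher number from compound 1 to compound 3 (0.04 log units; within the scatter), so compound 1 and compound 3 cannot be told apart here. This position, two atoms from the ring nitrogen, therefore tolerates losing the ring double bond and gaining a hydroxy group without a change beyond the scatter. Compound 2 gives only limits of the assay: the several entries of compound 2 in this assay, > 150000 nM; > 120000 nM (2 entries)

The compounds shown leave open how an amine or a carboxylic acid on this cyclohexyl ring would read in this assay. Also open, as far as these compounds go, is whether a plain cyclohexyl group, with no hydroxy group, would read the same.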